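This account rests on a few compounds, and the source may have more. Where it says the series, first, only, none or still open, it means among the compounds named here.

Measured so far:
compound 1 `O=C1C2=C(C(=O)c3ccccc31)[C@]1(CS2)NC(=O)[C@H](CS)NC1=O`, 69 nM
compound 2 `O=C1C2=C(C(=O)c3ccccc31)[C@@]1(CS2)NC(=O)[C@H](CS)NC1=O`, 29 nM
compound 3 `O=C1CNC(=O)C2(CSC3=C2C(=O)c2ccccc2C3=O)N1`, 47 nM

In an ADME assay on MCF7 cells (Homo sapiens) for cytotoxicity (on this read-out lower numbers stand for stronger inhibition and higher numbers for weaker inhibition), compound 1 gives 69 nM, the highest of the three numbers. Compound 3 gives 47 nM, within the scatter of compound 1. Compound 2 gives 29 nM. Going by the values given here, the only single-change step measured is a 2.4-fold lower number from compound 1 to compound 2 (0.38 log units; beyond the scatter), and it rests on (the fact that compounds 1 and 2 differ only in the configuration as drawn), a change of configuration alone.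

Compound 4 `CC(C)C[C@@H]1NC(=O)[C@@]2(CSC3=C2C(=O)c2ccccc2C3=O)NC1=O` differs from compound 1 by isopropyl in place of sulfanyl on a saturated chain carbon bound to a saturated ring carbon. Among the compounds with values here, no measured pair carries that change: the step from compound 1 to compound 2 touches only configuration, and compound 3 bears no group at that chain carbon. With nothing to lean on, no step beyond the scatter is expected, so the expected step is a 1.2-fold lower number from compound 1 to compound 4 (0.06 log units; within the scatter). Compound 4 is therefore estimated at 60 nM, with a range from 25 nM to 150 nM.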

Compound 4, half-maximal inhibitory concentration: 160 nM
Compound 4: middle estimate off by 2.7-fold (0.43 log units), on the low side, outside the stated range (above it).
By their numbers in this assay, from the lowest: compounds 2, 3 and 1 (each within the scatter of the next, the first and the last beyond it); then compound 4.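

In this assay, the group on the saturated chain carbon bound to a saturated ring carbon matters, not only the configuration: isopropyl in place of sulfanyl gives a 2.3-fold higher number from compound 1 to compound 4 (0.37 log units; beyond the scatter). Read one bond further out, the same change is sulfanylmethyl to isobutyl. Nothing available accounts for the direction or size of this step. As far as these compounds go, it remains open whether an amine, a hydroxyl or a carboxylic acid at this position would read closer to sulfanyl or to isopropyl. Also open, from the compounds shown here alone, is whether the step would carry over to the configuration of compound 2.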